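The source may hold more compounds than are shown below. What is called first, only, known or untested is meant among the compounds shown, and "the series" means these compounds.

For the measured compounds named here, compound 2, `COc1cc2c(Oc3ccc(NC(=O)c4nccc(-c5ccccc5)n4)cc3F)ccnc2cc1OCCCN1CCCCC1`, is the weaker of the two compounds measured so far in a functional assay on NCI-H460 cells (Homo sapiens) for cytotoxicity, read by MTT assay, with a stated time of 72 h; a lower number here means a stronger inhibitor, a higher number a weaker inhibitor: compound 2 gives 330 nM. Its closest relative among the measured compounds is compound 1, `COc1cc2c(Oc3ccc(NC(=O)c4cc(-c5ccccc5)ccn4)cc3F)ccnc2cc1OCCCN1CCCC1`, which differs from compound 2 in two places, in the aromatic ring that carries the amide and in the saturated ring at the end of the side chain. In this assay compound 1 gives 130 nM, a lower number than compound 2, and that gap lies beyond the usual scatter. Since the two compounds differ in two places at once, the numbers cannot say how much of the gap belongs to either change.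

Compound 3, `COc1cc2c(Oc3ccc(NC(=O)c4nccc(-c5ccccc5)n4)cc3F)ccnc2cc1OCCCN1CCCC1`, keeps the core of compound 2 and changes only the end of the side chain: pyrrolidin-1-yl in place of piperidin-1-yl on a saturated chain carbon, three bonds along the chain from an oxygen on an aromatic ring. Going by the values given here, no pair of measured compounds shows this change on its own. A step from compound 2 to compound 3 of a 1.3-fold lower number from compound 2 to compound 3 (0.12 log units; within the scatter) is expected, a modest move toward a lower number that stays within the scatter. For compound 3 in this assay the expected value is 250 nM, with a likely range from 110 nM to 550 nM.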

Compound 3, half-maximal inhibitory concentration: 1120 nM
Compound 3: middle estimate off by 4.5-fold (0.65 log units), on the low side, outside the stated range (above it).
By their numbers in this assay, from the lowest: compound 1; then compound 2; then compound 3.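

In this assay the change to pyrrolidin-1-yl in place of piperidin-1-yl, on a saturated chain carbon, three bonds along the chain from an oxygen on an aromatic ring, gives a 3.4-fold higher number from compound 2 to compound 3 (0.53 log units; beyond the scatter) and so shows that the end of the side chain is not a free choice here: with the 4-phenylpyrimidin-2-yl group on the amide, the six-membered ring gives the lower number and the five-membered ring the higher one. The second single change, 4-phenylpyrimidin-2-yl in place of 4-phenylpyridin-2-yl on a carbonyl carbon, gives an 8.6-fold higher number from compound 1 to compound 3 (0.94 log units; beyond the scatter) and is the larger of the two steps, so with the pyrrolidin-1-yl end held constant the ring carrying the amide also matters in this assay. Nothing available explains why either change moves the number in this direction.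

The compounds shown leave open whether the step between the two saturated rings keeps its size and direction when the amide carries 4-phenylpyridin-2-yl instead. They also leave open how a morpholin-4-yl or dimethylamino group at the end of the side chain, or a longer chain, would compare with these two rings.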